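From Cyclopropyl to Cyclobutyl: An Expected Shift

The source may report more compounds than this note shows. Statements on the series, on what has been measured and on what is new or still open speak of the compounds shown alone.

Going by the values given here, compound 2 `O=C(Nc1c(C(O)(C(F)(F)F)C(F)(F)F)ccc2ccccc12)C1CC1` gives 751 nM in an assay on LtK cells with ATP-sensitive inward rectifier potassium channel 11 (Homo sapiens) as the target (on this read-out higher numbers stand for an effect only at larger amounts of compound and lower numbers for an effect already at smaller amounts), the higher of the two numbers measured so far; compound 1 `CC(C)CCC(=O)Nc1c(C(O)(C(F)(F)F)C(F)(F)F)ccc2ccccc12` gives 49 nM. Compound 3 `O=C(Nc1c(C(O)(C(F)(F)F)C(F)(F)F)ccc2ccccc12)C1CCC1` differs from compound 2 by cyclobutyl in place of cyclopropyl on a carbonyl carbon. Among the compounds with values here, the single step measured in this assay, a 15-fold higher number from compound 1 to compound 2 (1.19 log units; beyond the scatter), replaced isopentyl with cyclopropyl. Going on to cyclobutyl reverses part of that change, so a lower number for compound 3 is expected, though a smaller move than that step. The estimate for compound 3 is 300 nM, within 120 nM to 750 nM, the expected step being a 2.5-fold lower number from compound 2 to compound 3 (0.40 log units; beyond the scatter).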

Compound 3, half-maximal effective concentration: 45 nM
Compound 3: middle estimate off by 6.7-fold (0.82 log units), on the high side; measured number below the stated range.
By their numbers in this assay, from the lowest: compounds 3 and 1 (each within the scatter of the next); then compound 2.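

In this assay, the four-membered ring behaves very differently from the three-membered ring: a 17-fold lower number from compound 2 to compound 3 (1.22 log units; beyond the scatter) follows from cyclobutyl replacing cyclopropyl on the carbonyl carbon. Having a ring at this position therefore does not by itself raise the number, and a 1.1-fold lower number from compound 1 to compound 3 (0.04 log units; within the scatter) shows cyclobutyl matching the open isopentyl chain within the scatter. Nothing available explains the sharp difference between the two rings. On these data alone, whether larger rings such as cyclopentyl or cyclohexyl keep the number this low remains open. So does the effect of a shorter chain such as ethyl, or of an amine on the ring.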